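The source may report more compounds than this note shows. Statements on the series, on what has been measured and on what is new or still open speak of the compounds shown alone.

Measured in a functional assay on PBMC cells (Homo sapiens) for inhibition; a higher number here means a weaker inhibitor, a lower number a stronger inhibitor:
compound 1 `NC(=O)CC[C@H](N)C(=O)NS(=O)(=O)OC[C@H]1O[C@@H](n2cnc3c(N)ncnc32)[C@H](O)[C@@H]1O` gives 800 nM
compound 2 `CC(C)C[C@H](N)C(=O)NS(=O)(=O)OC[C@H]1OC[C@@H](n2cnc3c(N)ncnc32)[C@H](O)[C@@H]1O` gives 1000 nM
compound 3 `Nc1ncnc2c1ncn2[C@@H]1CO[C@H](COS(=O)(=O)NC(=O)[C@@H]2CCCN2)[C@@H](O)[C@H]1O` gives 750 nM

Compound 1 stands second highest of these three numbers, but the numbers of compound 3 and of compound 2 both lie within the usual scatter of its own, so the three compounds cannot be told apart on this assay. The unmeasured compound 4 `N=C(N)NCCC[C@H](N)C(=O)NS(=O)(=O)OC[C@H]1O[C@@H](n2cnc3c(N)ncnc32)[C@H](O)[C@@H]1O` differs from compound 1 in one place: a group of 5 heavy atoms (2 carbon, 3 nitrogen; no ring) in place of a group of 3 heavy atoms (1 carbon, 1 nitrogen, 1 oxygen; no ring), on a saturated chain carbon, three bonds along the chain from an amine nitrogen and a carbonyl carbon. Among the compounds with values here, only one step between measured compounds is known, a 1.3-fold lower number from compound 2 to compound 3 (0.12 log units; within the scatter), which also exchanges the group on the carbonyl carbon and makes no difference beyond the scatter. Within the data shown here, that step bears only loosely on the present change, since it concerns a different pair of groups, yet it is the only guide, and all three variations of this part of the molecule gave numbers that cannot be separated. Compound 4 is therefore expected to give a number within the usual scatter of the measured ones, a step of no change at the digits printed from compound 1 to compound 4 (within the scatter). The estimate for compound 4 is 800 nM, with a range from 300 nM to 2200 nM.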

Compound 4, half-maximal inhibitory concentration: 1000 nM
Estimate against measurement, compound 4: 1.3-fold (0.10 log units) below, and the stated range covers the measured number.
By their numbers in this assay, from the lowest: compounds 3, 1, 2 and 4 (each within the scatter of the next).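

In this assay, a group of 5 heavy atoms with 3 hydrogen-bond donors in place of carbamoyl, which has 1, gives a 1.3-fold higher number from compound 1 to compound 4 (0.10 log units; within the scatter) and so cannot be told apart from no change. Within the data shown here, this is the first step measured on the core of compound 1 itself, and it shows that at this saturated chain carbon, even an exchange that adds heavy atoms and hydrogen-bond donors does not move the number beyond the scatter. No separate measurement bears on this result.

Still open, on these data alone, is whether a carboxylic acid on this chain carbon, or a plain amine at the end of a longer chain, would give a number beyond the scatter. A simple methyl in place of carbamoyl would show whether this position needs such a group at all.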